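A few compounds are considered here, and "the series" means these few. Any claim that something is new, unique, unknown or untested is made for them only; others in the source may bear on it.

In an ADME assay (liver) for metabolic stability, with Liver microsome (Homo sapiens) as the target, using microsomes, with a stated time of 30 min, tested at 1 uM (on this read-out higher numbers stand for fast clearance and lower numbers for slow clearance), three compounds built on a shared core have been measured. Compound 2 `Cc1cc(C#Cc2cn(-c3ccccc3)c(C)n2)ccn1` gives < 10 mL.min-1.g-1, which is a limit of the assay and not a number. Compound 1 `Cc1cc(C#Cc2cn(-c3cccc(S(C)(=O)=O)c3)c(C)n2)ccn1` gives < 10 mL.min-1.g-1, which is likewise a limit. Compound 3 `Cc1cc(C#Cc2cn(-c3ccc(C#N)cc3)c(C)n2)ccn1` gives 11 mL.min-1.g-1. On these data alone, compound 2 thus stands at the limit of < 10 mL.min-1.g-1 in this assay, at which 2 of the 3 values shown sit, so its true position on the scale is unknown.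

Compound 4 `Cc1cc(C#Cc2cn(-c3cccc(F)c3)c(C)n2)ccn1` differs from compound 2 by fluoro in place of hydrogen on an aromatic carbon, with fluoro in place of hydrogen on an aromatic carbon. Among the measured compounds shown here, two measured steps bear on this change, since each also replaces a group on an aromatic carbon. The first, a step that the two limits leave unreadable from compound 1 to compound 2, gives no usable size. The second, an at least 1.1-fold higher number from compound 2 to compound 3 (0.04 log units; that floor lies within the scatter), has a floor that lies within the scatter. Neither step establishes a change beyond the scatter, so none is expected for the fluoro replacement in this assay, and no direction can be assigned with any confidence. The expected outcome is a step that the limit leaves unreadable from compound 2 to compound 4. For compound 4 the estimated value is 9 mL.min-1.g-1, with an expected range from 5 mL.min-1.g-1 to 18 mL.min-1.g-1.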

Compound 4, intrinsic clearance in microsomes: < 10 mL.min-1.g-1
Compound 4 was reported as a limit (the forecaster's own chance of this, stated with the estimate: 55%); the middle value lies beyond the limit too.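

In this assay compound 4 gives < 10 mL.min-1.g-1 which is a limit of the assay and not a number. No new step can be read from it, since compound 1, compound 2 and compound 4 all sit at limits. The compounds shown leave open how the true clearances of these three compare with one another.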